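The compounds below may be only part of what the source reports. "The series", "measured", "known", "first", "only" and "open" are said of these compounds alone.

Measured so far in a functional assay, read by spectrophotometry, with a stated time of 5 min; on this read-out lower numbers stand for stronger inhibition and higher numbers for weaker inhibition:
compound 1 `COc1cc(/C=C/C(=O)C(=Cc2ccc(OC)c(OC)c2)C(=O)/C=C/c2ccc(O)c(OC)c2)ccc1O`, 71000000 nM
compound 2 `CCOc1cc(C=C(C(=O)/C=C/c2ccc(O)c(OC)c2)C(=O)/C=C/c2ccc(O)c(OC)c2)ccc1O`, 123000000 nM
compound 3 `CCOc1cc(/C=C/C(=O)C(=Cc2ccc(OC)c(OC)c2)C(=O)/C=C/c2ccc(O)c(OCC)c2)ccc1O`, 53200000 nM

Compound 2 differs from compound 1 by 3-ethoxy-4-hydroxyphenyl in place of 3,4-dimethoxyphenyl on a double-bonded chain carbon bound to a double-bonded chain carbon, and that change gave a 1.7-fold higher number from compound 1 to compound 2 (0.24 log units; within the scatter). The difference between the core of compound 1 and the core of compound 3 is not broken down here; compound 3 stands lowest of the three numbers, within the scatter of compound 1 and beyond it against compound 2. Compound 4 `CCOc1cc(C=C(C(=O)/C=C/c2ccc(O)c(OCC)c2)C(=O)/C=C/c2ccc(O)c(OCC)c2)ccc1O` is not yet measured. It differs from compound 3 by 3-ethoxy-4-hydroxyphenyl in place of 3,4-dimethoxyphenyl on a double-bonded chain carbon bound to a double-bonded chain carbon, the same change at the same place as between compound 1 and compound 2. Among the measured compounds shown here, only that one earlier step is available to go on, so the expected step is a 1.7-fold higher number from compound 3 to compound 4 (0.23 log units; within the scatter), resting on a 1.7-fold higher number from compound 1 to compound 2 (0.24 log units; within the scatter). Compound 4 is accordingly expected to give about 90000000 nM in this assay, estimated between 40000000 nM and 200000000 nM, the range kept wide with a single precedent.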

Compound 4, half-maximal inhibitory concentration: 96700000 nM
Estimate against measurement, compound 4: 1.1-fold (0.03 log units) below, within the range that was stated.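

In this assay, 3-ethoxy-4-hydroxyphenyl in place of 3,4-dimethoxyphenyl on a double-bonded chain carbon bound to a double-bonded chain carbon gives a 1.8-fold higher number from compound 3 to compound 4 (0.26 log units; within the scatter) on the core of compound 3, and this matches the earlier step on the core of compound 1: the same change on two cores in this assay, a 1.7-fold higher number (0.24 log units; within the scatter) from compound 1 to compound 2 and a 1.8-fold higher number (0.26 log units; within the scatter) from compound 3 to compound 4, 1.0-fold (0.02 log units) apart, within the scatter of two such steps. The change therefore carries over between these two cores with a similar size. Each step lies within the scatter on its own, however, so neither shows that the change itself moves the number, and two cores set no rule for the series.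

As far as these compounds go, it remains open whether this agreement extends to other groups at this place, such as a longer alkoxy chain like propoxy, an amine or a carboxylic acid. A step large enough to stand beyond the scatter would test the carry-over more firmly.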